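A Hydroxyphenyl Arm Gives Way to Methylthiophene

The source may report more compounds than this note shows. Statements on the series, on what has been measured and on what is new or still open speak of the compounds shown alone.

Measured so far:
Compound 1, `O=C(/C(=C\c1ccc(O)cc1)S(=O)(=O)Cc1ccc(F)cc1)c1ccc(Br)cc1`: 10000 nM
Compound 2, `O=C(/C(=C\c1ccc(OCc2ccccc2)cc1)SCc1ccc(Cl)cc1)c1ccc(Cl)cc1`: 1000 nM

Both compounds were tested in a functional assay on DU-145 cells (Homo sapiens) for inhibition, read by trypan blue exclusion, with a stated time of 96 h; a lower number here means a stronger inhibitor of growth, a higher number a weaker inhibitor of growth. Compound 1 gives 10000 nM, which is the highest of the two numbers. Compound 2 gives 1000 nM, a lower number, and the gap between these two lies beyond the usual scatter, so compound 2 is the stronger growth inhibitor of the pair.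

Compound 3, `Cc1ccc(/C=C(\C(=O)c2ccc(Br)cc2)S(=O)(=O)Cc2ccc(F)cc2)s1`, is not yet measured. It differs from compound 1 in one place: 5-methylthiophen-2-yl in place of 4-hydroxyphenyl on a double-bonded chain carbon bound to a double-bonded chain carbon. Going by the values given here, compound 1 and compound 2 differ in several places at once, so no single measured step shows what this particular exchange does, and the direction of the change cannot be read from the numbers at hand.

The step of a 1.7-fold lower number from compound 1 to compound 3 (0.22 log units; within the scatter) is therefore expected to be small, within or only slightly beyond the scatter, with a lean toward a somewhat lower number. For compound 3 in this assay the estimate is 6000 nM, with a range from 1500 nM to 20000 nM.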

Compound 3, concentration for 50% growth inhibition: 1000 nM
Compound 3: the middle estimate sits 6.0-fold (0.78 log units) above what was measured; measured number below the stated range.
By their numbers in this assay, from the lowest: compounds 2 and 3 (each within the scatter of the next); then compound 1.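

Going by these compounds alone, with the rest of the molecule held fixed, the group on a double-bonded chain carbon bound to a double-bonded chain carbon clearly matters: in this assay the exchange of 4-hydroxyphenyl for 5-methylthiophen-2-yl gives a 10-fold lower number from compound 1 to compound 3 (1.00 log units; beyond the scatter) and this is the first step here that changes one place only. The hydroxyl-bearing ring is therefore not required for growth inhibition in this pair, since the group that enters has no hydrogen-bond donor and compound 3 still gives the lower number. The exchange changes several things together, including a six-membered carbon ring becoming a five-membered ring with a sulfur atom, the loss of the hydroxyl and the arrival of a methyl, and no accompanying measurement explains the step or separates these changes.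

Still open, on these data alone, is how a plain phenyl, a 4-methoxyphenyl or a thiophen-2-yl without the methyl would behave at this position on the same core. Such groups could show whether the step follows the loss of the hydroxyl, the change of ring or the added methyl.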